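Amide ring swap on the shared core

The compounds below may be only part of what the source reports. "The series", "measured", "known", "first", "only" and "open" are said of these compounds alone.

Compound 1 `N#Cc1c(NC(=O)C2CCC2)sc2c1CCCC2` gives 1800 nM in a functional assay on RKE cells for antagonist activity at Vasoactive intestinal polypeptide receptor 1 (Rattus norvegicus), read by HTRF and cAMP accumulation, with stated times of 10 min and 30 min; a higher number here means a weaker inhibitor, a lower number a stronger inhibitor; compound 2 `N#Cc1c(NC(=O)C2CCCC2)sc2c1CCCC2` gives 470 nM in this assay, the lowest of the two numbers, with the step of a 3.8-fold lower number from compound 1 to compound 2 (0.58 log units; beyond the scatter) lying beyond the scatter. Compound 3 `N#Cc1c(NC(=O)c2ccccc2)sc2c1CCCC2` carries phenyl in place of cyclopentyl on a carbonyl carbon. Among the compounds with values here, only the step from compound 1 to compound 2 bears on this change, and it concerns one saturated ring replacing a smaller saturated ring, not an aromatic ring entering, so it gives no firm direction. The expected step of a 1.2-fold lower number from compound 2 to compound 3 (0.07 log units; within the scatter) is therefore small, within or close to the scatter. Compound 3 is estimated at 400 nM, range 100 nM to 1600 nM.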

Compound 3, half-maximal inhibitory concentration: 15000 nM
Beside the measured number, compound 3's estimate is 38-fold (1.57 log units) below it; measured number outside the range, above it.
By their numbers in this assay, from the lowest: compound 2; then compound 1; then compound 3.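

Phenyl on the carbonyl carbon gives the first rise in the number in this assay, with a large step (a 32-fold higher number from compound 2 to compound 3 (1.50 log units; beyond the scatter)) that reverses the gain seen among the saturated rings. It also ends above the smaller saturated ring (an 8.3-fold higher number from compound 1 to compound 3 (0.92 log units; beyond the scatter)), so the order does not follow ring size across the three compounds. Nothing measured here accounts for the loss with the aromatic ring.

On these data alone, whether a cyclohexyl ring would continue the fall from cyclobutyl to cyclopentyl remains open. Also open, as far as these compounds go, is whether the rise is specific to phenyl or would recur with a pyridyl ring or a benzyl group on the same carbonyl carbon.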